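The compounds below may be only part of what the source reports. "The series", "measured", "known", "first", "only" and "open" are said of these compounds alone.

Compound 3 `O=C(N/N=C/c1ccc(O)c(O)c1)c1cccnc1Nc1cccc(C(F)(F)F)c1` stands second highest of the three compounds measured in a functional assay on the whole organism (strain Wistar) for inhibition, with Rattus norvegicus as the target, read by paw edema, with a stated time of 3 h, at a dose of 10 mg/kg by the intraperitoneal route; a higher number here means more inhibition at the dose given (going by the name of the read-out), a lower number less inhibition. In this assay compound 3 gives 38.2%. Its nearest neighbour is compound 1 `O=C(N/N=C/c1cccc(F)c1)c1cccnc1Nc1cccc(C(F)(F)F)c1`, which in this assay gives 37%; the step of a number 1.2 percentage points higher from compound 1 to compound 3 (within the scatter) is within the scatter. The highest number belongs to compound 2 `O=C(N/N=C/c1ccc(Cl)cc1)c1cccnc1Nc1cccc(C(F)(F)F)c1`, which in this assay gives 48.5%; the step of a number 10.3 percentage points lower from compound 2 to compound 3 (beyond the scatter) is modest but beyond the scatter, as is the step of a number 11.5 percentage points higher from compound 1 to compound 2 (beyond the scatter).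

Compound 4 `COc1cccc(/C=N/NC(=O)c2cccnc2Nc2cccc(C(F)(F)F)c2)c1` has not yet been measured. It differs from compound 3 in one place: 3-methoxyphenyl in place of 3,4-dihydroxyphenyl on a carbon with a double bond to nitrogen. All three measured steps exchange the aryl group on the carbon with a double bond to nitrogen, and together they span only a modest range. Going by the values given here, no measured step introduces 3-methoxyphenyl, so the direction is open. Compound 4 is therefore expected to give 41%, with a range from 30% to 53%. The expected step from compound 3 is estimated at a number 2.8 percentage points higher from compound 3 to compound 4 (within the scatter), within the scatter.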

Compound 4, a percentage reported as inhibition, in the whole organism at one dose (the size of the read-out at that dose, not a potency): 30.3%
Compound 4: middle estimate off by 10.7 percentage points, on the high side; the range from low to high includes it.
By their numbers in this assay, from the lowest: compounds 4, 1 and 3 (each within the scatter of the next); then compound 2.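

On the carbon with a double bond to nitrogen, 3-methoxyphenyl replaces 3,4-dihydroxyphenyl, giving a number 7.9 percentage points lower from compound 3 to compound 4 (within the scatter), so in this assay this exchange, which removes the hydrogen-bond donors counted on the group, shows no effect that can be told from the scatter. Methoxy in place of fluoro on an aromatic carbon gives a number 6.7 percentage points lower from compound 1 to compound 4 (within the scatter), so these two groups cannot be told apart here either. The step to 4-chlorophenyl is the only kind that clears the scatter, with a number 18.2 percentage points lower from compound 2 to compound 4 (beyond the scatter), which leaves compound 2 alone at the top while compound 1, compound 3 and compound 4 form one group.

Going by these compounds, whether an amine or a carboxylic acid at this place would move the number beyond the scatter stays open. Nothing available explains why 4-chlorophenyl stands apart from the other three aryl groups.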